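The source may hold more compounds than are shown below. What is called first, only, known or untested is meant among the compounds shown, and "the series" means these compounds.

Measured compounds:

compound 1, `CCCCNS(=O)(=O)c1ccc(Nc2ncc3c(n2)N(C2CCCC2)[C@H](CC)C(=O)N3C)cc1`, 1610 nM
compound 2, `CCCNS(=O)(=O)c1ccc(Nc2ncc3c(n2)N(C2CCCC2)[C@H](CC)C(=O)N3C)cc1`, 2100 nM
compound 3, `CCCNC(=O)c1ccc2c(ccn2-c2ncc3c(n2)N(c2ccn(C)n2)C(CC)C(=O)N3C)c1`, 11000 nM

The three measured compounds were tested in a functional assay on NCI-H1975 cells (Homo sapiens) for antiproliferative activity, read by CCK-8 assay, with a stated time of 72 h; a lower number here means a stronger inhibitor of growth, a higher number a weaker inhibitor of growth. Compound 1 gives 1610 nM and compound 2 gives 2100 nM; the step between them, a 1.3-fold lower number from compound 2 to compound 1 (0.12 log units; within the scatter), is the change (methyl in place of hydrogen on a saturated chain carbon, three bonds along the chain from a sulfonamide nitrogen). Compound 3 gives 11000 nM, the highest of the three numbers; the difference between its core and that of compound 2 is not broken down here.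

Compound 4, `CCCCNC(=O)c1ccc2c(ccn2-c2ncc3c(n2)N(c2ccn(C)n2)C(CC)C(=O)N3C)c1`, has not yet been measured. It differs from compound 3 by methyl in place of hydrogen on a saturated chain carbon, three bonds along the chain from an amide-type nitrogen. Among the compounds with values here, this is the same kind of change as the one from compound 2 to compound 1, though the place is not identical: in the measured pair the saturated chain carbon lies three bonds along the chain from a sulfonamide nitrogen, whereas in compound 4 it lies three bonds along the chain from an amide-type nitrogen. On the evidence of the measured pair the chain extension barely moved the number, so a similarly small step is expected here. The expected step is a 1.2-fold lower number from compound 3 to compound 4 (0.09 log units; within the scatter), resting on the measured step of a 1.3-fold lower number from compound 2 to compound 1 (0.12 log units; within the scatter) and on the starting point of compound 3 at 11000 nM. Compound 4 is therefore estimated at 9000 nM in this assay, with a likely range from 4000 nM to 20000 nM.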

Compound 4, concentration for 50% growth inhibition: 12000 nM
The estimate for compound 4 lay 1.3-fold (0.12 log units) below the measured number; the range from low to high includes it.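

In this assay, the change from propyl to butyl, methyl in place of hydrogen on a saturated chain carbon three bonds along the chain from an amide-type nitrogen, comes with a 1.1-fold higher number from compound 3 to compound 4 (0.04 log units; within the scatter), so this step, like the earlier one, cannot be told apart from repeated measurement. Set side by side, the two steps do not differ, and in this small set the change carries from one core to the other without a visible effect on the number: the same change on two cores in this assay, a 1.3-fold lower number (0.12 log units; within the scatter) from compound 2 to compound 1 and a 1.1-fold higher number (0.04 log units; within the scatter) from compound 3 to compound 4, 1.4-fold (0.15 log units) apart, within the scatter of two such steps What this does not show is that the two cores respond to the change in the same way in any finer sense, for two steps that both lie within the scatter show only that no effect was seen on either core, and the two pairs also differ in carrying a sulfonamide nitrogen or an amide-type nitrogen, so that they give no separate reading of the core and of that linking group.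

The compounds shown leave open what a longer chain than butyl, a branched chain, or a chain ending in an amine or a carboxylic acid would do at this place. They also leave open whether the propyl to butyl change would read the same on any third core.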